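Cytotoxicity of a thiazolidinone series: from nitrophenyl to pyridyl

The source may hold more compounds than are shown below. What is called first, only, known or untested is meant among the compounds shown, and "the series" means these compounds.

Measured compounds:
- compound 1, `Cc1ccc(/C=C2/S/C(=N/c3ccccc3)N(Cc3ccncc3)C2=O)cc1`: 49500 nM
- compound 2, `O=C1/C(=C\c2ccc([N+](=O)[O-])cc2)S/C(=N/c2ccccc2)N1Cc1ccncc1`: 250000 nM
- compound 3, `COc1ccc(OC)c(/C=C2/S/C(=N/c3ccccc3)N(Cc3ccncc3)C2=O)c1`: 80100 nM

In an ADME assay on HEK293 cells (Homo sapiens) for cytotoxicity, read by MTT assay, with a stated time of 48 h (a higher number here means a weaker inhibitor, a lower number a stronger inhibitor), compound 2 gives the highest of the three numbers, 250000 nM. Its nearest neighbour is compound 3, which sits a 3.1-fold lower number from compound 2 to compound 3 (0.49 log units; beyond the scatter), and the largest step is a 5.1-fold higher number from compound 1 to compound 2 (0.70 log units; beyond the scatter), both beyond the scatter. Compound 1 and compound 3 lie within the scatter of each other (a 1.6-fold higher number from compound 1 to compound 3 (0.21 log units; within the scatter)).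

Compound 4, `O=C1/C(=C\c2ccccn2)S/C(=N/c2ccccc2)N1Cc1ccncc1`, has not yet been measured in this assay. It differs from compound 2 as follows: pyridin-2-yl in place of 4-nitrophenyl on a double-bonded chain carbon bound to a double-bonded ring carbon.

Both measured steps that touch compound 2 replace the 4-nitrophenyl group and both move the number down by a modest amount, beyond the scatter. With only these two examples, compound 4 is expected to follow the same direction, with a step of about a 2.8-fold lower number from compound 2 to compound 4 (0.44 log units; beyond the scatter). The estimate for compound 4 in this assay is therefore 90000 nM, with a likely range from 35000 nM to 250000 nM.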

Compound 4, half-maximal inhibitory concentration: 161000 nM
The estimate for compound 4 lay 1.8-fold (0.25 log units) below the measured number; the range from low to high includes it.
By their numbers in this assay, from the lowest: compounds 1, 3, 4 and 2 (each within the scatter of the next, the first and the last beyond it).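

At this position, on a double-bonded chain carbon bound to a double-bonded ring carbon, replacing 4-nitrophenyl does not always give a step beyond the scatter: pyridin-2-yl gives a 1.6-fold lower number from compound 2 to compound 4 (0.19 log units; within the scatter), whereas the 4-methylphenyl of compound 1 and the 2,5-dimethoxyphenyl of compound 3 each gave a step beyond it. In this assay, the replacement groups do not all behave alike, since pyridin-2-yl is clearly separated from 4-methylphenyl, with a 3.3-fold higher number from compound 1 to compound 4 (0.51 log units; beyond the scatter), but not from 2,5-dimethoxyphenyl, with a 2.0-fold higher number from compound 3 to compound 4 (0.30 log units; within the scatter). No measurement shown here explains these steps.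

The compounds shown leave open whether pyridin-3-yl or pyridin-4-yl at this position would give a number close to that of compound 4. They also leave open how a phenyl ring carrying an amine or a carboxylic acid would read here.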